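A few compounds are considered here, and "the series" means these few. Any claim that something is new, unique, unknown or untested is made for them only; others in the source may bear on it.

Compound 1 `COc1ccc(C(=O)c2cc(OC)c(OC)c(OC)c2)cc1[N+](=O)[O-]`: 2500 nM; compound 2 `COc1ccc(Cc2ccc(OC)c(OC)c2OC)cc1N`: 60 nM; compound 3 `COc1ccc(Cc2ccc(OC)c(OC)c2OC)cc1[N+](=O)[O-]`: 32 nM.

In a functional assay on HeLa cells (Homo sapiens) for cytotoxicity, read by XTT assay, with a stated time of 72 h (on this read-out higher numbers stand for weaker inhibition and lower numbers for stronger inhibition), compound 1 gives 2500 nM, the highest of the three numbers, while compound 3 gives 32 nM. The difference between the cores of compound 1 and compound 3 is not broken down here. On the core of compound 3, the change amino in place of nitro on an aromatic carbon leads to compound 2, which gives 60 nM; this is a 1.9-fold higher number from compound 3 to compound 2 (0.27 log units; within the scatter). Compound 4 `COc1ccc(C(=O)c2cc(OC)c(OC)c(OC)c2)cc1N` carries the same change on the core of compound 1: amino in place of nitro on an aromatic carbon. For the measured compounds named here, the step is expected to be a 1.6-fold higher number from compound 1 to compound 4 (0.20 log units; within the scatter), resting on a 1.9-fold higher number from compound 3 to compound 2 (0.27 log units; within the scatter), the only measured instance of this change. In this assay compound 4 is therefore estimated at 4000 nM, expected to fall between 1500 nM and 12000 nM.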

Compound 4, half-maximal inhibitory concentration: 30 nM
Estimate against measurement, compound 4: 130-fold (2.12 log units) above; measured number outside the range, below it.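

Amino in place of nitro does not carry over unchanged from one core to the other in this series: in this assay the step on the core of compound 1 is an 83-fold lower number from compound 1 to compound 4 (1.92 log units; beyond the scatter), so a step measured on one core did not predict the step on the other. The two pairs compare as follows: the same change on two cores in this assay, a 1.9-fold higher number (0.27 log units; within the scatter) from compound 3 to compound 2 and an 83-fold lower number (1.92 log units; beyond the scatter) from compound 1 to compound 4, 160-fold (2.19 log units) apart, beyond the scatter of two such steps. This rests on a single pair for each core and does not show which part of the difference between the cores matters, or how the change would behave on a further core.

Still open, going by these compounds, is how a hydroxyl or an acetamide group in this place would behave on either core. Also open, on these data alone, is whether the carbonyl alone separates the two cores' steps.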